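A few compounds are considered here, and "the series" means these few. Any claim that something is new, unique, unknown or untested is made for them only; others in the source may bear on it.

Measured so far in an ADME assay on a cell-free system (plasma, Homo sapiens) for metabolic stability, read by LC-MS; on this read-out lower numbers stand for a shorter-lived compound and higher numbers for a longer-lived compound:
- compound 1 `COC(=O)c1cccc(-c2cc(C(=O)Nc3ccncc3F)ccc2CN)c1`: 1.08 h
- compound 2 `NCc1ccc(C(=O)Nc2ccncc2F)cc1-c1cccc(C(=O)O)c1`: > 2 h

Compound 2 is known only as a limit, not as a number. Compound 3 `NCc1ccc(C(=O)Nc2ccncc2F)cc1-c1cccc(C(=O)OC2CCCOC2)c1` has oxan-3-yl in place of hydrogen on an oxygen next to a carbonyl group. Within the data shown here, the one measured step at this place is an at least 1.8-fold higher number from compound 1 to compound 2 (0.26 log units; that floor lies within the scatter). Compound 3 again carries a group on that oxygen, as does compound 1 at 1.08 h, so a shorter half-life is expected in this assay, with the size of the step uncertain. The expected step is an at least 1.5-fold lower number from compound 2 to compound 3 (0.18 log units; that floor lies within the scatter). For compound 3 the estimate is 1.3 h, with an expected range of 0.5 h to 2.5 h.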

Compound 3, half-life: 0.3 h
Compound 3: middle estimate off by 4.3-fold (0.64 log units), on the high side, and the stated range ends above it.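

In this assay, the identity of the group on an oxygen next to a carbonyl group matters, not only its presence: oxan-3-yl in place of methyl gives a 3.6-fold lower number from compound 1 to compound 3 (0.56 log units; beyond the scatter). Oxan-3-yl in place of hydrogen gives an at least 6.6-fold lower number from compound 2 to compound 3 (0.82 log units; beyond the scatter), a floor beyond the scatter, whereas the floor of the earlier step at this place lay within it. Compound 2 stands only as a limit: the limit of > 2 h in this assay, at which 1 of the 3 values shown sits.

On these data alone, the actual half-life of compound 2 remains open. Also open, as far as these compounds go, is whether an ethyl group or a longer chain on that oxygen would fall closer to compound 1 or to compound 3.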